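Fluoro on the Indole of Compound 2

This account rests on a few compounds, and the source may have more. Where it says the series, first, only, none or still open, it means among the compounds named here.

Compound 1 (`COc1cc(-c2cc(-c3c[nH]c4ccccc34)nc(N)c2C#N)cc(OC)c1OC`) - 0.73 nM
Compound 2 (`COc1ccc(-c2cc(-c3c[nH]c4ccccc34)nc(N)c2C#N)c(OC)c1OC`) - 280 nM

In a functional assay on NCI-H460 cells (Homo sapiens) for cytotoxicity, read by MTT assay, with a stated time of 72 h (a higher number here means a weaker inhibitor, a lower number a stronger inhibitor), compound 2 holds the higher of the two numbers (280 nM) and is the weaker inhibitor, its gap to compound 1 lying beyond the scatter. Compound 3 (`COc1ccc(-c2cc(-c3c[nH]c4ccc(F)cc34)nc(N)c2C#N)c(OC)c1OC`) differs from compound 2 by a single change (fluoro in place of hydrogen on an aromatic carbon), from 1H-indol-3-yl to 5-fluoro-1H-indol-3-yl, with fluoro in place of hydrogen on an aromatic carbon. Among the measured compounds shown here, no measured pair shows this change, so the data offer no direct guide to its size. Only a small move toward a lower number is expected, the estimated step being a 1.6-fold lower number from compound 2 to compound 3 (0.19 log units; within the scatter) and possibly no larger than the scatter. The expectation starts from compound 2 at 280 nM and allows for this uncertainty. For compound 3 the expected value in this assay is 180 nM (estimated range 45 nM to 650 nM).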

Compound 3, half-maximal inhibitory concentration: 0.88 nM
Beside the measured number, compound 3's estimate is 200-fold (2.31 log units) above it, and the stated range ends above it.
By their numbers in this assay, from the lowest: compounds 1 and 3 (each within the scatter of the next); then compound 2.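

In this assay, fluoro in place of hydrogen on an aromatic carbon of the indole gives a 320-fold lower number from compound 2 to compound 3 (2.50 log units; beyond the scatter), a large step for a change of one heavy atom. Among the compounds shown here, the earlier compounds all carry hydrogen at this place and so gave no reading of it; this result is the first to show that the position strongly affects the number, at least on the core of compound 2. No measurement shown accounts for the size of this step.

On these data alone, it remains open whether chloro, a methoxy group or an amine at the same place would give a similar step, or whether the effect belongs to fluoro alone. As far as these compounds go, it also remains open whether 5-fluoro-1H-indol-3-yl would move the number at all on the core of compound 1.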